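Dimethylamino to pyrrolidin-1-yl on the side chain

The compounds below may be only part of what the source reports. "The series", "measured", "known", "first", "only" and "open" are said of these compounds alone.

Measured in a functional assay on A549 cells (Homo sapiens) for antiproliferative activity, read by MTT assay, with a stated time of 48 h; on this read-out higher numbers stand for weaker inhibition and lower numbers for stronger inhibition
Compound 1 `Oc1ccc2cc1Oc1ccc(cc1)CCc1ccc(CN3CCN(Cc4ccccc4)CC3)c(O)c1-c1ccc(cc1O)CC2`: > 20000 nM (a limit)
Compound 2 `CN(C)CCCOc1cccc2c1-c1ccc(cc1O)CCc1ccc(O)c(c1)Oc1ccc(cc1)CC2`: 1990 nM

Compound 1 reads > 20000 nM, which is a limit and not a number. Among the compounds with values here, compound 2 therefore holds the only actual number in this assay, at 1990 nM.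

Compound 3 `Oc1ccc2cc1Oc1ccc(cc1)CCc1cccc(OCCCN3CCCC3)c1-c1ccc(cc1O)CC2` differs from compound 2 in one place: pyrrolidin-1-yl in place of dimethylamino on a saturated chain carbon, three bonds along the chain from an oxygen on an aromatic ring. It carries pyrrolidin-1-yl in place of dimethylamino on a saturated chain carbon, three bonds along the chain from an oxygen on an aromatic ring. Within the data shown here, no measured pair shows what such a change does. Starting from compound 2 at 1990 nM, no step beyond the usual scatter is expected in this assay, and the direction is left open. The expected step is small, an estimated 1.2-fold lower number from compound 2 to compound 3 (0.07 log units; within the scatter). For compound 3 the estimated value is 1700 nM, with an expected range of 600 nM to 5000 nM.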

Compound 3, half-maximal inhibitory concentration: 4530 nM
For compound 3 the middle estimate is 2.7-fold (0.43 log units) below the measured one; the range from low to high includes it.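

Placing pyrrolidin-1-yl in place of dimethylamino on a saturated chain carbon, three bonds along the chain from an oxygen on an aromatic ring, gives the first step that can be read at this position in this assay: a 2.3-fold higher number from compound 2 to compound 3 (0.36 log units; beyond the scatter). The higher number stands for weaker inhibition, so the five-membered ring costs a modest amount of activity here, yet compound 3 still gives an actual number and not a limit. The data shown give no cause for this step.

This rests on a single pair, so it sets no pattern for the amine on this chain. On these data alone, whether piperidin-1-yl, morpholin-4-yl or diethylamino would read nearer to compound 2 or to compound 3 stays open, as does the effect of a longer chain carrying the same amine.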